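Chloro position in the benzyl series: compound 2 to compound 3

A few compounds are considered here, and "the series" means these few. Any claim that something is new, unique, unknown or untested is made for them only; others in the source may bear on it.

In a functional assay on SK-MEL-28 cells (Homo sapiens) for inhibition, read by MTT assay, with a stated time of 48 h (on this read-out higher numbers stand for weaker inhibition and lower numbers for stronger inhibition), compound 1 `O=C1N/C(=N\Cc2ccccc2)S/C1=C1/CCNC(=O)c2[nH]ccc21` gives 38400 nM. Compound 2 `O=C1N/C(=N\Cc2ccc(Cl)cc2)S/C1=C1/CCNC(=O)c2[nH]ccc21` gives > 100000 nM, which is a limit of the assay and not a number. Compound 2 therefore has no exact position, and sits at the limit of > 100000 nM in this assay, at which 1 of the 2 values shown sits.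

Among the measured compounds shown here, the one measured step bearing on the change is an at least 2.6-fold higher number from compound 1 to compound 2 (0.41 log units; beyond the scatter), with chloro in place of hydrogen on an aromatic carbon. Compound 3 `O=C1N/C(=N\Cc2cccc(Cl)c2)S/C1=C1/CCNC(=O)c2[nH]ccc21` has 3-chlorophenyl in place of 4-chlorophenyl on a saturated chain carbon bound to a double-bonded nitrogen. For the measured compounds named here, no measured step covers a move of the chloro, so the expectation is loose. Compound 3 still carries a chloro and is expected to stay weak, not passing compound 1 at 38400 nM by much.

The expected change is an at least 1.4-fold lower number from compound 2 to compound 3 (0.15 log units; that floor lies within the scatter), towards a lower number in this assay. For compound 3 the estimate is 70000 nM, with an expected range of 35000 nM to 120000 nM.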

Compound 3, half-maximal inhibitory concentration: 34700 nM
For compound 3 the middle estimate is 2.0-fold (0.30 log units) above the measured one; the measured number lies below the stated range.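

In this assay, 3-chlorophenyl in place of 4-chlorophenyl gives an at least 2.8-fold lower number from compound 2 to compound 3 (0.45 log units; beyond the scatter), so the place of the chloro on this benzyl group matters, and not only its presence. The value of compound 2 is a limit of the assay and not a number, so this step has only a floor: the limit of > 100000 nM in this assay, at which 1 of the 3 values shown sits.

Chloro in place of hydrogen, read against the plain benzyl group, gives a 1.1-fold lower number from compound 1 to compound 3 (0.04 log units; within the scatter), so a chloro on the benzyl group does not always bring the loss that the 4-chlorobenzyl group shows.

The compounds shown leave open why the two chloro placements differ. They also leave open whether a methoxy or an amine on the benzyl ring, or a longer chain in place of the benzyl carbon, would follow the same pattern.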